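The compounds below may be only part of what the source reports. "The series", "measured", "known", "first", "only" and "open" are said of these compounds alone.

Working notes on the series. Compound 1 `O=C1c2ccccc2CN1c1cnc(NCc2c(F)ccc3c2CCO3)n2cnnc12` gives 13 mL.min-1.g-1 in an ADME assay on microsomes from liver (Homo sapiens) for metabolic stability, read by LC-MS, using NADPH, with stated times of 5 min and 30 min, tested at 1 uM; on this read-out higher numbers stand for fast clearance and lower numbers for slow clearance. Compound 2 `CN(c1ccccc1)c1cnc(NCc2c(F)ccc3c2CCO3)n2cnnc12` gives 55 mL.min-1.g-1 in this assay. Compound 3 `O=C1CC2(CC2)CN1c1cnc(NCc2c(F)ccc3c2CCO3)n2cnnc12` gives < 3 mL.min-1.g-1 in this assay, which is a limit of the assay rather than a number. Compound 3 is the slowest-cleared of the three, since both an at least 4.3-fold lower number from compound 1 to compound 3 (0.63 log units; beyond the scatter) and an at least 18-fold lower number from compound 2 to compound 3 (1.26 log units; beyond the scatter) lie beyond the scatter, whereas a 4.2-fold higher number from compound 1 to compound 2 (0.63 log units; beyond the scatter) runs upward.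

Compound 4 `CN(c1cccnc1)c1cnc(NCc2c(F)ccc3c2CCO3)n2cnnc12` differs from compound 3 by a group of 8 heavy atoms (6 carbon, 2 nitrogen; one six-membered aromatic ring with 1 hetero atom) in place of a group of 8 heavy atoms (6 carbon, 1 nitrogen, 1 oxygen; one three-membered non-aromatic ring of carbon only, one five-membered non-aromatic ring with 1 hetero atom), on an aromatic carbon. For the measured compounds named here, of the measured steps, the one from compound 2 to compound 3 bears most directly on this change, because compound 2 is the closest measured relative of compound 4 and that step was an at least 18-fold lower number from compound 2 to compound 3 (1.26 log units; beyond the scatter); the present change largely reverses it. A large upward step in this assay is therefore expected, estimated at an at least 10-fold higher number from compound 3 to compound 4 (1.00 log units; beyond the scatter), with the reading of compound 2, 55 mL.min-1.g-1, as the reference point. Compound 4 is expected to give 30 mL.min-1.g-1, within a range of 10 mL.min-1.g-1 to 80 mL.min-1.g-1.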

Compound 4, intrinsic clearance in microsomes: 80 mL.min-1.g-1
Estimate against measurement, compound 4: 2.7-fold (0.43 log units) below; the range from low to high includes it.
By their numbers in this assay, from the lowest: compound 1; then compounds 2 and 4 (each within the scatter of the next). At a limit, below all of these: compound 3.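

At this position on the aromatic carbon, pyridin-3-yl in place of phenyl on the amino nitrogen gives no readable shift in this assay (a 1.5-fold higher number from compound 2 to compound 4 (0.16 log units; within the scatter)), so the added ring nitrogen does not separate compound 4 from compound 2. Among the four compounds, the two methyl(aryl)amino groups therefore sit together at the fast-clearing end, and compound 4 lies beyond the scatter from the ring-closed carbonyl groups of compound 1 (a 6.2-fold higher number from compound 1 to compound 4 (0.79 log units; beyond the scatter)) and compound 3 (an at least 26-fold higher number from compound 3 to compound 4 (1.42 log units; beyond the scatter)). That last step has only a lower bound, as compound 3 stands at a limit of the assay: the limit of < 3 mL.min-1.g-1 in this assay, at which 1 of the 4 values shown sits.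

Going by these compounds, whether the methyl or the aromatic ring drives the difference from compound 1 and compound 3 stays open. Also open, on these data alone, is whether a saturated amine such as piperidin-1-yl on this carbon would read with compound 3 or with compound 4.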